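Trimming the ether from an aminothiadiazole amide

A few compounds are considered here, and "the series" means these few. Any claim that something is new, unique, unknown or untested is made for them only; others in the source may bear on it.

Within the data shown here, compound 2 `COCCNc1nnc(SCC(=O)N(Cc2cccc([N+](=O)[O-])c2)c2ccc(F)cc2)s1` is one of two compounds measured in an assay on isolated protein for inhibition of Amine oxidase [flavin-containing] B (Homo sapiens), read by fluorescence and Amplex Red, with a stated time of 30 min, tested at 100 uM (on this read-out lower numbers stand for a weaker effect and higher numbers for a stronger effect at the one concentration tested), where compound 2 gives 25.7% and compound 1 `CC(C)CNc1nnc(SCC(=O)N(Cc2cccc([N+](=O)[O-])c2)c2ccc(F)cc2)s1` gives 24.2%; the two numbers lie within the scatter of each other. Compound 3 `CCNc1nnc(SCC(=O)N(Cc2cccc([N+](=O)[O-])c2)c2ccc(F)cc2)s1` differs from compound 2 by hydrogen in place of methoxy on a saturated chain carbon, two bonds along the chain from a nitrogen on an aromatic ring. Among the measured compounds shown here, the only step at hand on this chain, a number 1.5 percentage points higher from compound 1 to compound 2 (within the scatter), stayed within the scatter, so another change on the same chain is expected to move the read-out in this assay by no more than the scatter, in no particular direction. Compound 3 is therefore expected at 24%, between 10% and 38%, a step of a number 1.7 percentage points lower from compound 2 to compound 3 (within the scatter).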

Compound 3, a percentage reported as inhibition, at one concentration (the size of the read-out at that concentration, not a potency): 22.4%
Compound 3: middle estimate off by 1.6 percentage points, on the high side; the range from low to high includes it.
By their numbers in this assay, from the lowest: compounds 3, 1 and 2 (each within the scatter of the next).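

In this assay, losing the methoxy keeps the read-out within the scatter (a number 3.3 percentage points lower from compound 2 to compound 3 (within the scatter)), and so does replacing the isopropyl with methyl (a number 1.8 percentage points lower from compound 1 to compound 3 (within the scatter)). The three chains on this nitrogen, ending in methoxymethyl, isopropyl or methyl, therefore cannot be told apart on this read-out, so neither the methoxy nor the isopropyl is shown to matter here. Nothing at hand bears on why this is so. The compounds shown leave open whether an amine or a carboxylic acid at the end of this chain, or a longer chain, would move the read-out beyond the scatter.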